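A Halogenated Aryl Group Enters an Inactive Series

This account rests on a few compounds, and the source may have more. Where it says the series, first, only, none or still open, it means among the compounds named here.

Measured compounds:
compound 1 `CCOc1ccccc1-n1nncc1CN1C(=O)C2(C(C#N)=C(N)Oc3c2c2nc4ccccc4nc2c2ccccc32)c2ccccc21`, in an ADME assay on L02 cells (Homo sapiens) for antiproliferative activity, read by MTT assay, with a stated time of 48 h (on this read-out lower numbers stand for stronger inhibition and higher numbers for weaker inhibition), compound 1 gives > 50000 nM, which is a limit of the assay.
compound 2 `N#CC1=C(N)Oc2c(c3nc4ccccc4nc3c3ccccc23)C12C(=O)N(Cc1cnnn1-c1ccc(N)cc1)c1ccccc12`, in this assay compound 2 gives > 50000 nM, again a limit.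
compound 3 `CC(=O)Nc1ccc(-n2nncc2CN2C(=O)C3(C(C#N)=C(N)Oc4c3c3nc5ccccc5nc3c3ccccc43)c3ccccc32)cc1`, in this assay compound 3 gives > 50000 nM, also a limit.

All three compounds share one core and differ only in the group carried by an aromatic nitrogen of the five-membered aromatic ring with 3 nitrogen. For the measured compounds named here, none of them reaches a measurable value, so compound 3 stands where every compound measured so far stands, at the limit of > 50000 nM in this assay, at which 3 of the 3 values shown sit. The three steps between them, a step that the two limits leave unreadable from compound 1 to compound 2, a step that the two limits leave unreadable from compound 1 to compound 3 and a step that the two limits leave unreadable from compound 2 to compound 3, therefore show no readable size or direction.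

Compound 4 `N#CC1=C(N)Oc2c(c3nc4ccccc4nc3c3ccccc23)C12C(=O)N(Cc1cnnn1-c1ccc(F)c(Cl)c1)c1ccccc12` continues the same kind of exchange on that aromatic nitrogen: 3-chloro-4-fluorophenyl in place of 4-acetamidophenyl on an aromatic nitrogen. The earlier steps shown here bear on it only in kind, not in size, and no measured value of a halogenated phenyl group is available. With every neighbour sitting at the limit, compound 4 is expected to sit there too, and the step that the limit leaves unreadable from compound 3 to compound 4 is expected to show no change beyond the scatter. The estimate for compound 4 in this assay is 60000 nM, within a range from 25000 nM to 150000 nM.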

Compound 4, half-maximal inhibitory concentration: > 50000 nM
Compound 4 gave a limit, no number (the forecaster's own chance of this, stated with the estimate: 80%); the middle value is on the limit's open side.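

Compound 4 is also held at a limit and gives no number, so the steps to it from compound 1, compound 2 and compound 3 cannot be read: the limit of > 50000 nM in this assay, at which 4 of the 4 values shown sit.

Still open, as far as these compounds go, is how these four compounds rank in this assay, and whether any group on that aromatic nitrogen would give a measurable value there.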